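The source may report more compounds than this note shows. Statements on the series, on what has been measured and on what is new or still open speak of the compounds shown alone.

Three amides that share one core have been tested in a toxicity assay on THP-1 cells (Homo sapiens) for inhibition; on this read-out lower numbers stand for higher toxicity in this test and higher numbers for lower toxicity in this test. Compound 1 `COc1ccc(-c2cnc(NC(=O)c3ccc(Br)cc3)n2C)cc1` gives > 100000 nM and this is a limit of the assay, not a number. Compound 2 `CCC(=O)Nc1ncc(-c2ccc(OC)cc2)n1C` gives > 100000 nM and this too is a limit. Compound 3 `COc1ccc(-c2cnc(NC(=O)c3cccc(Cl)c3)n2C)cc1` gives > 28000 nM and this is again a limit, so compound 3 has no exact reading, and neither does either of the others.

The next compound, compound 4 `COc1ccc(-c2cnc(NC(=O)C3CCCC3)n2C)cc1`, differs from compound 3 only on a carbonyl carbon, where cyclopentyl takes the place of 3-chlorophenyl: cyclopentyl in place of 3-chlorophenyl on a carbonyl carbon.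

Three measured steps change the same place. They are a step that the two limits leave unreadable from compound 1 to compound 2 and a step that the two limits leave unreadable from compound 1 to compound 3 and a step that the two limits leave unreadable from compound 2 to compound 3. None of them has a readable size, so none supplies a size to carry over to the new change. All that they show is that compounds 1, 2 and 3 each gave only a limit, with 4-bromophenyl, ethyl and 3-chlorophenyl in this place. No step beyond the usual scatter is therefore expected in this assay in either direction. The expected change is a step that the limit leaves unreadable from compound 3 to compound 4 in this test. Compound 4 is expected at about 60000 nM with an estimated range from 20000 nM to 150000 nM. It may well turn out that compound 4 also gives only a limit.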

Compound 4, half-maximal cytotoxic concentration: > 100000 nM
Compound 4: only a limit was reported (the forecaster's own chance of this, stated with the estimate: 85%); middle value at least 1.6-fold (0.22 log units) from the limit.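

Compound 4 also gave only a limit in this assay, so its steps from compound 1, compound 2 and compound 3 cannot be read. The compounds shown leave open whether any amide on the shared core has a measurable half-maximal cytotoxic concentration in this assay, and how the group on the carbonyl carbon would alter it.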